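Pyridin-3-yl in Place of the Oxazole: An Expected Partial Recovery

The source may report more compounds than this note shows. Statements on the series, on what has been measured and on what is new or still open speak of the compounds shown alone.

Compound 1 `Cc1c(-c2cc(Cl)cc(Cl)c2)c(C(=O)O)nn1-c1nc(-c2cc(Cl)cc(Cl)c2)c(SC(C)C)s1` carries 3,5-dichlorophenyl on an aromatic carbon of the shared core. In a functional assay on BJAB cells (Homo sapiens) for antiproliferative activity, with a stated time of 4 days (a higher number here means that more compound is needed for the effect, a lower number that less compound is needed), compound 1 gives 2000 nM. Compound 2 `Cc1oncc1-c1nc(-n2nc(C(=O)O)c(-c3cc(Cl)cc(Cl)c3)c2C)sc1SC(C)C` carries 5-methyl-1,2-oxazol-4-yl in place of that group. Compound 2 yields only a limit in this assay, > 44000 nM, and it sits at the limit of > 44000 nM in this assay, at which 1 of the 2 values shown sits. The change registers as an at least 22-fold higher number from compound 1 to compound 2 (1.34 log units; beyond the scatter), a large loss. Compound 3 `Cc1c(-c2cc(Cl)cc(Cl)c2)c(C(=O)O)nn1-c1nc(-c2cccnc2)c(SC(C)C)s1` has not yet been measured; it carries pyridin-3-yl in place of 5-methyl-1,2-oxazol-4-yl on an aromatic carbon. Among the measured compounds shown here, the one step that bears on it is the loss from compound 1 to compound 2. Since pyridin-3-yl shares the six-membered ring of 3,5-dichlorophenyl but not its chlorines, and since an at least 22-fold higher number from compound 1 to compound 2 (1.34 log units; beyond the scatter) was the cost of giving that group up entirely, compound 3 is expected to recover only part of it, a step of an at least 2.9-fold lower number from compound 2 to compound 3 (0.46 log units; beyond the scatter). Compound 3 is accordingly estimated at 15000 nM, within a range from 4000 nM to 60000 nM.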

Compound 3, half-maximal effective concentration: "not active" (no number reported)
No number was reported for compound 3; the estimate stays without a comparison.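

In this assay, among the compounds shown here, compound 3 is reported only as not active, without a number, so no step from compound 2 to compound 3 can be read. Open remains how far pyridin-3-yl on the shared core differs numerically from 5-methyl-1,2-oxazol-4-yl or 3,5-dichlorophenyl.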